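The source may hold more compounds than are shown below. What is called first, only, known or untested is meant among the compounds shown, and "the series" means these compounds.

Measured compounds:
- compound 1, `CC(C)OC(=O)N1CCC(O[C@H]2CC[C@H](Oc3cnc(S(C)(=O)=O)cn3)CC2)CC1`, 120%
- compound 2, `CS(=O)(=O)c1cnc(O[C@H]2CC[C@H](OC3CCN(C(=O)OC4CCOC4)CC3)CC2)cn1`, 109%
- compound 3, `CS(=O)(=O)c1cnc(O[C@H]2CC[C@H](OC3CCN(CC4(C(F)(F)F)CCC4)CC3)CC2)cn1`, 99%

All three values come from a functional assay on isolated protein for agonist activity at Glucose-dependent insulinotropic receptor (Rattus norvegicus), read by HTRF and cAMP accumulation; on this read-out lower numbers stand for smaller maximal responses and higher numbers for larger maximal responses. Compound 3 gives the lowest of the three numbers in this assay; its nearest neighbour is compound 2, a difference that lies within the scatter, while the gap to compound 1 is beyond the scatter. The measured steps on the ring amine nitrogen are a number 21 percentage points lower from compound 1 to compound 3 (beyond the scatter) and a number 10 percentage points lower from compound 2 to compound 3 (within the scatter), and on the oxygen next to the carbonyl group a number 11 percentage points lower from compound 1 to compound 2 (beyond the scatter).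

Compound 4, `CC(C)c1noc(CN2CCC(O[C@H]3CC[C@H](Oc4cnc(S(C)(=O)=O)cn4)CC3)CC2)n1`, differs from compound 3 by 3-isopropyl-1,2,4-oxadiazol-5-yl in place of 1-(trifluoromethyl)cyclobutyl on a saturated chain carbon bound to an amine nitrogen in a ring; cut one bond further out, this reads (1-(trifluoromethyl)cyclobutyl)methyl to (3-isopropyl-1,2,4-oxadiazol-5-yl)methyl. Among the measured compounds shown here, no measured step alters this part of the molecule, so only the spread of the three values sets the expectation. In this assay compound 4 is expected to give 105%, between 90% and 122%. The expected step is a number 6 percentage points higher from compound 3 to compound 4 (within the scatter), within the scatter.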

Compound 4, largest response reached (Emax), in percent of the reference or control that the assay uses: 115%
Compound 4: middle estimate off by 10 percentage points, on the low side; the measured number falls inside the stated range.
By their numbers in this assay, from the lowest: compounds 3, 2, 4 and 1 (each within the scatter of the next, the first and the last beyond it).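

In this assay, the place on a saturated chain carbon bound to an amine nitrogen in a ring now has its first measured step (a number 16 percentage points higher from compound 3 to compound 4 (beyond the scatter)): 3-isopropyl-1,2,4-oxadiazol-5-yl in place of 1-(trifluoromethyl)cyclobutyl, with 8 heavy atoms in each group. The response therefore depends on which group sits at this carbon, not only on the presence of a carbon-linked group on the ring amine nitrogen. Compound 4 has no carbonyl on that nitrogen, yet its steps from the two carbonyl-bearing compounds stay within the scatter (a number 5 percentage points lower from compound 1 to compound 4 (within the scatter); a number 6 percentage points higher from compound 2 to compound 4 (within the scatter)).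

No measurement here bears on why the two groups differ. As far as these compounds go, it remains open how a cyclopropyl group in place of the isopropyl on the oxadiazole, or a longer chain in place of the methyl link, would read in this assay.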